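The source may report more compounds than this note shows. Statements on the series, on what has been measured and on what is new or still open speak of the compounds shown alone.

Measured so far:
Compound 1, `CCOC(=O)c1c(-c2cc3ccccc3oc2=O)nn(-c2cccc(Cl)c2)c1C(=O)OCC`: 28000 nM
Compound 2, `COC(=O)c1c(-c2cc3ccccc3oc2=O)nn(-c2cccc(Cl)c2)c1C(=O)OC`: 30000 nM
Compound 3, `CCOC(=O)c1c(-c2cc3ccccc3oc2=O)nn(-c2cccc(F)c2)c1C(=O)OCC`: 59000 nM

All three were tested in a functional assay on A549 cells (Homo sapiens) for cytotoxicity, read by MTT assay, with a stated time of 48 h; a lower number here means a stronger inhibitor, a higher number a weaker inhibitor. Compound 1 gives 28000 nM and compound 2 gives 30000 nM in this assay; the two values lie within the scatter of each other, so nothing separates them. How the core of compound 1 and the core of compound 2 differ is not broken down here.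

Compound 3 is compound 1 with one change, (fluoro in place of chloro on an aromatic carbon). This change made a step of a 2.1-fold higher number from compound 1 to compound 3 (0.32 log units; beyond the scatter), which lies beyond the scatter, though only modestly.

Compound 4, `COC(=O)c1c(-c2cc3ccccc3oc2=O)nn(-c2cccc(F)c2)c1C(=O)OC`, has not yet been measured. It stands to compound 2 as compound 3 stands to compound 1: the change is fluoro in place of chloro on an aromatic carbon. The place of the change is described in the same words for both pairs, so this is the same change made on the core of compound 2 instead of the core of compound 1.

Going by the values given here, the only guide to what compound 4 will do is the one measured example of this change. Compound 4 is expected to show a step of a 2.1-fold higher number from compound 2 to compound 4 (0.32 log units; beyond the scatter), and this expectation rests on the step of a 2.1-fold higher number from compound 1 to compound 3 (0.32 log units; beyond the scatter) seen once before. For compound 4 the estimated value in this assay is 63000 nM, with a likely range from 35000 nM to 110000 nM.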

Compound 4, half-maximal inhibitory concentration: 50000 nM
Compound 4: the middle estimate sits 1.3-fold (0.10 log units) above what was measured; the measured number falls inside the stated range.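

In this assay, exchanging 3-chlorophenyl for 3-fluorophenyl on the core of compound 2 gives a 1.7-fold higher number from compound 2 to compound 4 (0.22 log units; within the scatter), so on this core the change does not clearly separate the two compounds. Set beside the earlier example, the step agrees with it, and as far as this assay can tell, the change behaved alike on both cores: the same change on two cores in this assay, a 2.1-fold higher number (0.32 log units; beyond the scatter) from compound 1 to compound 3 and a 1.7-fold higher number (0.22 log units; within the scatter) from compound 2 to compound 4, 1.3-fold (0.10 log units) apart, within the scatter of two such steps. Going by these compounds alone, this shows that the step carried over between two closely related cores, but with only two pairs, one just beyond the scatter and the other within it, it does not fix the true size of the step or show that it would hold on a more different core.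

The compounds shown leave open what other groups would do at the same place on the aromatic ring, such as a methyl, a methoxy, a nitrile or an amine, since only chloro and fluoro appear there. They also leave open how the series would respond if a carboxylic acid or an amide stood in place of the ester groups, or how the chloro to fluoro exchange would behave on such a core.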